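From benzyl ester to benzyl ether on a shared core

The source may report more compounds than this note shows. Statements on the series, on what has been measured and on what is new or still open speak of the compounds shown alone.

In a functional assay on HT-29 cells (Homo sapiens) for antiproliferative activity, read by MTT assay, with a stated time of 48 h (a lower number here means a stronger inhibitor, a higher number a weaker inhibitor), compound 1 `O=C(OCc1ccccc1)c1cc(-c2ccc(Cl)cc2)nc2cc(Cl)c(Cl)cc12` gives 48700 nM and compound 2 `COc1ccc(-c2cc(C(=O)OCc3ccccc3)c3cc(Cl)c(Cl)cc3n2)cc1` gives 42200 nM. These two lie within the scatter of each other, with a step of a 1.2-fold lower number from compound 1 to compound 2 (0.06 log units; within the scatter). Among the measured compounds shown here, compound 3 `COc1ccc(-c2cc(COCc3ccccc3)c3cc(C)ccc3n2)cc1`, the only measured compound bearing (benzyloxy)methyl, reads > 100000 nM, and this is a limit of the assay, not a number (the limit of > 100000 nM in this assay, at which 1 of the 3 values shown sits).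

Compound 4 `COc1ccc(-c2cc(COCc3ccccc3)c3cc(Cl)c(Cl)cc3n2)cc1` departs from compound 2 in one place: (benzyloxy)methyl stands in place of benzyloxycarbonyl on an aromatic carbon, opposite the ring nitrogen ((benzyloxy)methyl in place of benzyloxycarbonyl on an aromatic carbon). For the measured compounds named here, no measured step covers this exchange, since the one available, the methoxy for chloro swap of a 1.2-fold lower number from compound 1 to compound 2 (0.06 log units; within the scatter), concerns another group and stayed within the scatter. Going by the values given here, the only hint is the reading of compound 3 at > 100000 nM, so a modest move toward a weaker number in this assay is expected, with low confidence. The expected step is a 1.3-fold higher number from compound 2 to compound 4 (0.12 log units; within the scatter). For compound 4 the estimated value is 55000 nM, within an expected range of 25000 nM to 100000 nM.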

Compound 4, half-maximal inhibitory concentration: > 100000 nM
Compound 4 gave a limit, no number (the forecaster's own chance of this, stated with the estimate: 30%); at least 1.8-fold (0.25 log units) between middle value and limit.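

Among the compounds shown here, on the shared core, this position, opposite the ring nitrogen, is the first place where a single exchange moves the reading in this assay beyond the scatter: (benzyloxy)methyl in place of benzyloxycarbonyl gives an at least 2.3-fold higher number from compound 2 to compound 4 (0.37 log units; beyond the scatter). For the compounds shown here, the only earlier step, methoxy in place of chloro on an aromatic carbon, stayed within the scatter, so the benzyloxycarbonyl position is the one of the two that shows a change. The reading of compound 4 is a limit and not a number, so the step gives only a minimum and its full size stays unknown: the limit of > 100000 nM in this assay, at which 2 of the 4 values shown sit.

What the compounds shown leave open is whether the carbonyl alone accounts for the step or the whole ester linkage does. As far as these compounds go, whether an amide, a carboxylic acid or a hydroxymethyl at this position would keep the reading of compound 2 also remains open.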